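The source may hold more compounds than are shown below. What is called first, only, known or untested is meant among the compounds shown, and "the series" means these compounds.

In an ADME assay on MT4 cells (Homo sapiens) for cytotoxicity, with a stated time of 5 days (a higher number here means that more compound is tolerated, a lower number that less compound is tolerated), compound 1 `CC(C)(C)C#Cc1cc(N(C(=O)[C@H]2CC[C@H](C)CC2)[C@H]2CC[C@H](Oc3ccccn3)CC2)c(C(=O)O)s1` gives > 20000 nM, which is a limit of the assay and not a number. Compound 2 `CC1CC=C(C(=O)N(c2cc(C#CC(C)(C)C)sc2C(=O)O)C(C)C)CC1` likewise reaches only a limit in this assay, > 20000 nM. Compound 3 `C[C@H]1CC[C@H](C(=O)N(c2cc(C#CC3(C(F)(F)F)CCC3)sc2C(=O)O)[C@H]2CC[C@H](Oc3ccc(=O)[nH]n3)CC2)CC1` also gives a limit, > 20000 nM. Compound 1 therefore stands at the limit of > 20000 nM in this assay, at which 3 of the 3 values shown sit, alongside every other measured compound. Compound 4 `CC(C)(C)C#Cc1cc(N(C(=O)[C@H]2CC[C@H](C)CC2)[C@H]2CC[C@H](OC3CCOCC3)CC2)c(C(=O)O)s1` differs from compound 1 in one place: oxan-4-yl in place of pyridin-2-yl on an oxygen on a saturated carbon. Among the measured compounds shown here, no pair of measured compounds differing in a single place is available, so the size of this step cannot be read from measured data. Since all three measured values sit at the limit of > 20000 nM in this assay, at which 3 of the 3 values shown sit, the expected step is a step that the limit leaves unreadable from compound 1 to compound 4, none beyond the scatter. Compound 4 is estimated at 30000 nM, with a range from 15000 nM to 100000 nM, most likely reported again only as a limit.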

Compound 4, half-maximal cytotoxic concentration: > 20000 nM
Compound 4: no number, only a limit; the forecaster's own chance of this, stated with the estimate: 90%; the middle value is on the limit's open side.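

No step can be read between compound 1 and compound 4, since each reaches only a limit in this assay: the limit of > 20000 nM in this assay, at which 4 of the 4 values shown sit.

The compounds shown leave open whether any structural change here would give a readable cytotoxic concentration in this assay.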